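This account rests on a few compounds, and the source may have more. Where it says the series, first, only, none or still open, it means among the compounds named here.

Three close relatives share one core: compound 1 `C=CC(=O)Nc1ccc(-c2nc(Cl)cc(Nc3ccc(C(=O)Nc4ccc(OC)cc4)cc3)n2)cc1`, compound 2 `C=CC(=O)Nc1ccc(-c2nc(Cl)cc(Nc3ccc(C(=O)Nc4cccc(C)c4)cc3)n2)cc1` and compound 3 `C=CC(=O)Nc1ccc(-c2nc(Cl)cc(Nc3ccc(C(=O)Nc4cc(C(F)(F)F)cc(C(F)(F)F)c4)cc3)n2)cc1`. In a functional assay on Ramos cells (Homo sapiens) for antiproliferative activity, read by MTT assay, with a stated time of 48 h (on this read-out higher numbers stand for weaker inhibition and lower numbers for stronger inhibition), compound 2 gives 5390 nM, the lowest of the two numbers reported; compound 3 gives 6180 nM, a gap that lies within the usual scatter, so the two cannot be ranked against each other. For compound 1 the entry in this assay reads "not determined" (no result reported), so no number is available for it.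

Compound 4 `C=CC(=O)Nc1ccc(-c2nc(Cl)cc(Nc3ccc(C(=O)N(C)C)cc3)n2)cc1` changes compound 2 in one place: dimethylamino in place of (3-methylphenyl)amino on a carbonyl carbon. Among the measured compounds shown here, no measured pair shows the effect of such a change, and the two numbers in hand sit on the same level, so there is little to anchor a direction. The expectation for compound 4 is a modest move towards weaker inhibition, the step of a 1.5-fold higher number from compound 2 to compound 4 (0.17 log units; within the scatter), giving an estimated 8000 nM with a likely range from 3000 nM to 20000 nM.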

Compound 4, half-maximal inhibitory concentration: > 50000 nM
Compound 4 was reported as a limit; the forecaster's own chance of this, stated with the estimate: 20%; middle value at least 6.2-fold (0.79 log units) away from the limit.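

In this assay, the group on this carbonyl carbon proves to matter: dimethylamino in place of (3-methylphenyl)amino gives an at least 9.2-fold higher number from compound 2 to compound 4 (0.96 log units; beyond the scatter). Compound 2 and compound 3 both keep an aromatic ring on this amide and sit on one level, so they could not show this loss. The value for compound 4 is a limit, not a number: the limit of > 50000 nM in this assay, at which 1 of the 4 values shown sits.

Still open, as far as these compounds go, is which part of the change counts, the lost aromatic ring or the lost amide hydrogen, since the two go together here. A methylamino group on the same carbonyl carbon would keep that hydrogen without the ring.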